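Amide-nitrogen variation in the series: estimate for compound 4

A few compounds are considered here, and "the series" means these few. Any claim that something is new, unique, unknown or untested is made for them only; others in the source may bear on it.

Compound 1, `CN(C)CCNC(=O)c1c(O)c2cccnc2n(-c2ccccc2)c1=O`: 22.6%
Compound 2, `COc1cccc(NC(=O)c2c(O)c3cccnc3n(-c3ccccc3)c2=O)c1`: 5.7%
Compound 3, `O=C(Nc1cccc([N+](=O)[O-])c1)c1c(O)c2cccnc2n(-c2ccccc2)c1=O`: 5.7%

In a functional assay on the whole organism for inhibition, with Rattus norvegicus as the target, read by paw edema, at a dose of 100 mg/kg by the oral route (a higher number here means more inhibition at the dose given (going by the name of the read-out), a lower number less inhibition), compound 3 stands level with compound 2 at the digits shown, the two together at the bottom of the three readings; compound 1 stands above both, and the gap a number 16.9 percentage points lower from compound 1 to compound 3 (beyond the scatter) lies beyond the scatter, as does a number 16.9 percentage points lower from compound 1 to compound 2 (beyond the scatter).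

The step under consideration is (pyridin-3-yl)methyl in place of 3-nitrophenyl on an amide-type nitrogen, giving compound 4, `O=C(NCc1cccnc1)c1c(O)c2cccnc2n(-c2ccccc2)c1=O`.

Two kinds of measured step bear on it. Swapping one aryl group on the amide-type nitrogen for another, no change at the digits printed from compound 2 to compound 3 (within the scatter), left the reading unchanged within the scatter. Replacing the 2-(dimethylamino)ethyl chain by an aryl group, a number 16.9 percentage points lower from compound 1 to compound 3 (beyond the scatter) and a number 16.9 percentage points lower from compound 1 to compound 2 (beyond the scatter), lowered the reading modestly. Among the compounds with values here, compound 4 carries neither an aryl group directly on the nitrogen nor the chain of compound 1, but a one-carbon linked heteroaryl group, so no measured step matches it directly. Since aryl-for-aryl exchange gave nothing, and only the move away from the directly attached aryl has been linked with a larger reading, a small rise is expected but one that may stay within the scatter: the step expected is a number 6.3 percentage points higher from compound 3 to compound 4 (within the scatter). For compound 4 the estimate in this assay is 12%, with a range from 0% to 28%.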

Compound 4, a percentage reported as inhibition, in the whole organism at one dose (the size of the read-out at that dose, not a potency): 25.5%
Compound 4: middle estimate off by 13.5 percentage points, on the low side, within the range that was stated.
By their numbers in this assay, from the lowest: compounds 2 and 3 (each within the scatter of the next); then compounds 1 and 4 (each within the scatter of the next).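

In this assay the group on the amide-type nitrogen decides more than the aryl-for-aryl exchange suggested: a number 19.8 percentage points higher from compound 3 to compound 4 (beyond the scatter) and a number 19.8 percentage points higher from compound 2 to compound 4 (beyond the scatter), so (pyridin-3-yl)methyl sets compound 4 apart from both compounds carrying a directly attached aryl group. Against the chain of compound 1, the reading is a number 2.9 percentage points higher from compound 1 to compound 4 (within the scatter), so among these compounds the dimethylamino group is not required for a reading at this level, and a chain ending in an aromatic ring with one hetero atom serves as well in this assay. Nothing available explains the difference between the (pyridin-3-yl)methyl and aryl groups at this position.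

The compounds shown leave open whether the higher reading follows the one-carbon link on the nitrogen or the ring nitrogen of the pyridine: a benzyl group and a directly attached pyridin-3-yl group on the amide-type nitrogen would separate the two. Also open, going by these compounds, is how the reading responds to a longer link, as in a 2-(pyridin-3-yl)ethyl group, or to a different ring position, as in a (pyridin-4-yl)methyl group.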